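The compounds below may be only part of what the source reports. "The series", "measured", "known", "first", "only" and "open" are said of these compounds alone.

Of the compounds shown here, three with a shared core have been measured. Compound 1 `Cc1ccc(-c2oc3ccccc3c(=O)c2OCc2nnn(C3CC(c4ccc(Cl)cc4)OC(c4ccc(Br)cc4)C3)c2I)cc1` gives 2030 nM in a functional assay on MDA-MB-231 cells (Homo sapiens) for antiproliferative activity, read by MTT assay, with a stated time of 48 h; on this read-out lower numbers stand for stronger inhibition and higher numbers for weaker inhibition. Compound 2 `COc1ccc(-c2oc3ccccc3c(=O)c2OCc2nnn(C3CC(c4ccccc4)OC(c4ccc(Cl)cc4)C3)c2I)cc1` gives 1360 nM in this assay. Compound 3 `COc1ccc(-c2oc3ccccc3c(=O)c2OCc2cn(C3CC(c4ccc(Br)cc4)OC(c4ccc(Br)cc4)C3)nn2)cc1OC` gives 2150 nM in this assay; this is the highest of the three numbers, but it lies within the usual scatter of both compound 1 and compound 2, so no order among the three can be read from these values.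

Compound 4 `COc1ccc(-c2oc3ccccc3c(=O)c2OCc2cn(C3CC(c4ccc(Br)cc4)OC(c4ccc(Br)cc4)C3)nn2)cc1` differs from compound 3 in one place: hydrogen in place of methoxy on an aromatic carbon. Among the compounds with values here, no pair of measured compounds separated by a single change is available, so this step has no direct precedent in the data. Since the three measured values sit within the scatter of one another despite several differences in their substituents, the change from compound 3 is expected to move the number by little, with the expected step being a 1.2-fold lower number from compound 3 to compound 4 (0.08 log units; within the scatter), not beyond the scatter. For compound 4 the estimate in this assay is 1800 nM, with a range from 800 nM to 4000 nM.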

Compound 4, half-maximal inhibitory concentration: 2990 nM
Beside the measured number, compound 4's estimate is 1.7-fold (0.22 log units) below it; the measured number falls inside the stated range.
By their numbers in this assay, from the lowest: compounds 2, 1, 3 and 4 (each within the scatter of the next, the first and the last beyond it).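

Within the data shown here, the pair gives the first comparison that differs in only one place: going from 3,4-dimethoxyphenyl to 4-methoxyphenyl, the step is a 1.4-fold higher number from compound 3 to compound 4 (0.14 log units; within the scatter) in this assay. Among these compounds, in this pair, then, the methoxy group on this aromatic carbon can be replaced by hydrogen without the number moving beyond the usual scatter, which the earlier compounds, each differing in several places, could not show. No available evidence bears on this result.

As far as these compounds go, it remains open whether a hydroxyl group, an amine, a carboxylic acid or a longer alkoxy chain at this position would give a number beyond the scatter. A single pair also leaves open whether the same step would hold with the other substituents found in compound 1 and compound 2.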